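A few compounds are considered here, and "the series" means these few. Any claim that something is new, unique, unknown or untested is made for them only; others in the source may bear on it.

Measured compounds:
- compound 1 `O=C1C=C(C(O)c2ccc(Cl)cc2)C(=O)c2ccccc21`, in a functional assay on WHCO1 cells (Homo sapiens) for cytotoxicity, read by MTT assay, with a stated time of 24 h (on this read-out lower numbers stand for stronger inhibition and higher numbers for weaker inhibition), compound 1 gives 3000 nM
- compound 2 `O=C(C1=CC(=O)c2ccccc2C1=O)c1ccc(Cl)cc1`, in this assay compound 2 gives 72900 nM
- compound 3 `Cc1cc(Cl)ccc1C(O)C1=CC(=O)c2ccccc2C1=O`, in this assay compound 3 gives 3400 nM

Compound 3 carries the change methyl in place of hydrogen on an aromatic carbon relative to compound 1, and the step it made was a 1.1-fold higher number from compound 1 to compound 3 (0.05 log units; within the scatter). Compound 2 stands apart from the other two: how its core differs from that of compound 1 is not broken down here, and its value lies well beyond the scatter from both. For the measured compounds named here, compound 4 `Cc1cc(Cl)ccc1C(=O)C1=CC(=O)c2ccccc2C1=O` bears the change methyl in place of hydrogen on an aromatic carbon relative to compound 2, the same change as the one from compound 1 to compound 3. Since that earlier step lay within the scatter, the step of a 1.1-fold higher number from compound 2 to compound 4 (0.04 log units; within the scatter) is expected to be small as well, resting only on the pair compound 1 and compound 3. Compound 4 is therefore estimated at 80000 nM, between 30000 nM and 200000 nM.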

Compound 4, half-maximal inhibitory concentration: 50400 nM
Estimate against measurement, compound 4: 1.6-fold (0.20 log units) above; the range from low to high includes it.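

In this assay, methyl in place of hydrogen on an aromatic carbon gave a 1.4-fold lower number from compound 2 to compound 4 (0.16 log units; within the scatter). Set beside the earlier step, the change behaves alike on the two cores: the same change on two cores in this assay, a 1.1-fold higher number (0.05 log units; within the scatter) from compound 1 to compound 3 and a 1.4-fold lower number (0.16 log units; within the scatter) from compound 2 to compound 4, 1.6-fold (0.21 log units) apart, within the scatter of two such steps. For the compounds shown here, this shows that the change carried from one core to the other without a step beyond the scatter, but it rests on only two pairs and does not show that it would do so on any other core.

The compounds shown leave open whether an ethyl or a methoxy group at the same place would behave like methyl. Also open, on these data alone, is what an amine or a carboxylic acid in place of the chloro group would do on either core.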